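This account rests on a few compounds, and the source may have more. Where it says the series, first, only, none or still open, it means among the compounds named here.

Working notes on the series. For the measured compounds named here, the shared core is carried by compound 2 `CCOC(=O)c1cnc(-c2csc(C)n2)nc1NN1C(=O)C=C(C)C1=O`, which in a functional assay on Jurkat cells for inhibition of nuclear factor NF-kappa-B complex (Homo sapiens) (a higher number here means a weaker inhibitor, a lower number a stronger inhibitor), gives 8000 nM; this is the highest of the three numbers measured so far. Compound 1 `CCOC(=O)c1cnc(-c2cc(Cl)nc(Cl)c2)nc1NN1C(=O)C=C(C)C1=O` gives 2000 nM in this assay, and compound 3 `CCOC(=O)c1cnc(-c2ccc(C(F)(F)F)cc2)nc1NN1C(=O)C=C(C)C1=O` gives 400 nM. Between them the steps run as follows: a 4.0-fold higher number from compound 1 to compound 2 (0.60 log units; beyond the scatter); a 5.0-fold lower number from compound 1 to compound 3 (0.70 log units; beyond the scatter); and a 20-fold lower number from compound 2 to compound 3 (1.30 log units; beyond the scatter).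

The next compound, compound 4 `CCOC(=O)c1cnc(-c2cccc([N+](=O)[O-])c2)nc1NN1C(=O)C=C(C)C1=O`, differs from compound 2 in one place: 3-nitrophenyl in place of 2-methyl-1,3-thiazol-4-yl on an aromatic carbon. The step that bears most directly on this change is a 20-fold lower number from compound 2 to compound 3 (1.30 log units; beyond the scatter), where a six-membered aromatic ring of carbon only likewise entered in place of the 2-methyl-1,3-thiazol-4-yl group. The step of a 4.0-fold higher number from compound 1 to compound 2 (0.60 log units; beyond the scatter) points the same way, with the thiazolyl compound at the weak end. A lower number in this assay is therefore expected for compound 4, with the expected step being a 10-fold lower number from compound 2 to compound 4 (1.00 log units; beyond the scatter). How far the 3-nitrophenyl group tracks the 4-(trifluoromethyl)phenyl group is not shown by the data, so the range is kept wide. For compound 4 the estimate in this assay is 800 nM, within 250 nM to 2500 nM.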

Compound 4, half-maximal inhibitory concentration: 7000 nM
Compound 4: middle estimate off by 8.8-fold (0.94 log units), on the low side; measured number outside the range, above it.
By their numbers in this assay, from the lowest: compound 3; then compound 1; then compounds 4 and 2 (each within the scatter of the next).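

In this assay, a six-membered aromatic ring of carbon only at this position does not by itself give the lower number: 3-nitrophenyl shows a 1.1-fold lower number from compound 2 to compound 4 (0.06 log units; within the scatter) against 2-methyl-1,3-thiazol-4-yl. The two carbon-only rings also stand far apart, with an 18-fold higher number from compound 3 to compound 4 (1.24 log units; beyond the scatter) on going from 4-(trifluoromethyl)phenyl to 3-nitrophenyl, so the ring type alone does not set the number here. For the compounds shown here, the pyridine-bearing compound also separates from the nitro compound, with a 3.5-fold higher number from compound 1 to compound 4 (0.54 log units; beyond the scatter) as the step, leaving 4-(trifluoromethyl)phenyl the only group here that gives a number clearly below that of 2,6-dichloropyridin-4-yl.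

Nothing available accounts for the gap between the two phenyl groups. The compounds shown leave open whether the substituent or its place on the ring drives that gap, and how an amine or a carboxylic acid on the phenyl ring would read.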